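This account rests on a few compounds, and the source may have more. Where it says the series, first, only, none or still open, it means among the compounds named here.

Compound 1, `C=C[C@@](C)(/C=C/c1ccc(OCc2ccccc2)cc1)CCC=C(C)C`, in an ADME assay on HEK293 cells (Homo sapiens) for cytotoxicity, with a stated time of 72 h (a higher number here means that more compound is needed for the effect, a lower number that less compound is needed), gives > 36600 nM, which is a limit of the assay rather than a number. Compound 2, `C=C[C@@](C)(/C=C/c1ccc(O)cc1)CCC(O)C(C)(C)O`, gives > 36600 nM in this assay, again a limit. Compound 3, `CC(C)=CCC[C@](C)(/C=C/c1ccc(O)cc1)/C=C/c1ccc(C#N)cc1`, gives > 36600 nM in this assay, also a limit.

Compound 1 thus stands at the limit of > 36600 nM in this assay, at which 3 of the 3 values shown sit, and no number sets it apart from the others. Compound 4, `C=C[C@@](C)(/C=C/c1ccc(-c2ccc(Cl)cc2)cc1)CCC=C(C)C`, differs from compound 1 by 4-chlorophenyl in place of benzyloxy on an aromatic carbon. Within the data shown here, no pair of measured compounds shows a step for this change, and with every value at the limit neither size nor direction of a step can be read; the expectation is therefore no step beyond the scatter. Compound 4 is expected to give about 36600 nM in this assay, within 12000 nM to 110000 nM. The expected step is a number no higher from compound 1 to compound 4 (the limit leaves the size open).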

Compound 4, half-maximal effective concentration: > 36600 nM
Compound 4: no number, only a limit; the forecaster's own chance of this, stated with the estimate: 70%; the middle value lies on the limit itself.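

Compound 1 and compound 4 both stand at a limit in this assay rather than at a number, so no step between them can be read: the limit of > 36600 nM in this assay, at which 4 of the 4 values shown sit.

The compounds shown leave open how much of any of them is needed for the effect, and whether 4-chlorophenyl in place of benzyloxy changes that amount.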